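A few compounds are considered here, and "the series" means these few. Any claim that something is new, unique, unknown or untested is made for them only; others in the source may bear on it.

Measured so far:
compound 1 `O=C(O)C1CCN(c2ccccc2)C1` — 48000 nM
compound 2 `O=C(O)C1CCN(c2ccccc2Cl)C1` — 19000 nM

In an assay on cells for inhibition of Palmitoleoyl-protein carboxylesterase NOTUM variant C330S (Homo sapiens), read by fluorescence, with a stated time of 40 min (on this read-out higher numbers stand for weaker inhibition and lower numbers for stronger inhibition), compound 1 gives the highest of the two numbers; its nearest neighbour is compound 2, at a 2.5-fold lower number from compound 1 to compound 2 (0.40 log units; beyond the scatter). Compound 3 `O=C(O)C1CCN(c2ccc(C(F)(F)F)cc2)C1` is not yet measured. It differs from compound 1 by trifluoromethyl in place of hydrogen on an aromatic carbon, the trifluoromethyl sitting on the six-membered aromatic ring of carbon only, para to a group of 8 heavy atoms. Among the measured compounds shown here, only the step from compound 1 to compound 2 bears on this, a modest substitution effect on the same ring, so a modest lowering is expected for compound 3, about a 3.0-fold lower number from compound 1 to compound 3 (0.48 log units; beyond the scatter). Compound 3 is therefore estimated at 16000 nM, within 5000 nM to 48000 nM.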

Compound 3, half-maximal inhibitory concentration: 50000 nM
Estimate against measurement, compound 3: 3.1-fold (0.49 log units) below, outside the stated range (above it).
By their numbers in this assay, from the lowest: compound 2; then compounds 1 and 3 (each within the scatter of the next).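

In this assay trifluoromethyl in place of hydrogen on an aromatic carbon, para to a group of 8 heavy atoms, gives a 1.0-fold higher number from compound 1 to compound 3 (0.02 log units; within the scatter) and so leaves the core of compound 1 where it stood. The lowering seen in a 2.5-fold lower number from compound 1 to compound 2 (0.40 log units; beyond the scatter) with chloro therefore does not extend to every substitution on this ring, though those two steps differ in both group and place. Nothing at hand accounts for this result.

Going by these compounds, whether chloro at this same carbon would lower the number remains open. So does the effect of an amine or a methoxy group there.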